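A few compounds are considered here, and "the series" means these few. Any claim that something is new, unique, unknown or untested is made for them only; others in the source may bear on it.

Compound 1 `COc1ccc(-c2nc(CNC(=O)c3cccnc3)sc2-c2ccc(OC)cc2)cc1` is one of three related compounds measured in a functional assay (aorta) with Rattus norvegicus as the target; on this read-out higher numbers stand for an effect only at larger amounts of compound and lower numbers for an effect already at smaller amounts. In this assay compound 1 gives 8.2 uM, the highest of the three numbers, although each gap to the others lies within the scatter. Compound 2 `COc1ccc(-c2nc(CNC(=O)CSc3ccccc3)sc2-c2ccc(OC)cc2)cc1` gives 4.2 uM, and compound 3 `COc1ccc(-c2nc(CNC(=O)C3=NNC(=O)CC3)sc2-c2ccc(OC)cc2)cc1` gives 7.3 uM. The measured steps are a 2.0-fold lower number from compound 1 to compound 2 (0.29 log units; within the scatter) and a 1.1-fold lower number from compound 1 to compound 3 (0.05 log units; within the scatter), and between the other two a 1.7-fold higher number from compound 2 to compound 3 (0.24 log units; within the scatter). Each of these steps exchanges only the group on the carbonyl carbon, leaving the rest of the shared core untouched. Among the compounds with values here, compound 4 `COc1ccc(-c2nc(/C=C/C(=O)O)sc2-c2ccc(OC)cc2)cc1` changes something else: 2-carboxyethenyl in place of (((pyridin-3-yl)carbonyl)amino)methyl on an aromatic carbon No measured step touches this part of compound 1, so none gives a direct guide. Within the data shown here, they show only that exchanging the group on the carbonyl carbon left the number within the scatter, which says nothing about replacing the whole side chain. Compound 4 is therefore expected to give 12 uM, with a likely range from 3 uM to 50 uM. This estimate means the step of a 1.5-fold higher number from compound 1 to compound 4 (0.17 log units; within the scatter) is expected, with wide uncertainty.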

Compound 4, concentration for half-maximal effect: 55 uM
Compound 4: middle estimate off by 4.6-fold (0.66 log units), on the low side; the whole stated range lies below it.
By their numbers in this assay, from the lowest: compounds 2, 3 and 1 (each within the scatter of the next); then compound 4.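

Within the data shown here, exchanging the whole (((pyridin-3-yl)carbonyl)amino)methyl side chain for 2-carboxyethenyl on this aromatic carbon gives in this assay a 6.7-fold higher number from compound 1 to compound 4 (0.83 log units; beyond the scatter) and is the only step here beyond the scatter. Among these compounds, the earlier exchanges all kept the amide and changed only the group on the carbonyl carbon, and they stayed within the scatter, so this position is the first place in the set where a change moves the number clearly. No measurement shown gives a reason for this step.

From the compounds shown here alone, the step removes the amide and the pyridine ring and brings in a carboxylic acid all at once, so the part responsible remains open. A saturated 2-carboxyethyl chain, a methyl ester or an amine at this position would help separate these changes.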